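Sulfonamide heteroaryl swap on a shared core: compound 4

The source may hold more compounds than are shown below. What is called first, only, known or untested is meant among the compounds shown, and "the series" means these compounds.

Measured compounds in a functional assay on OVCAR-4 cells (Homo sapiens) for inhibition, read by sulforhodamine B assay, with a stated time of 48 h; on this read-out lower numbers stand for higher toxicity in this test and higher numbers for lower toxicity in this test:
compound 1 `C=C1CC[C@@H]2[C@](C)(COC(C)=O)[C@H](OC(C)=O)CC[C@@]2(C)[C@H]1CC(Nc1ccc(S(=O)(=O)Nc2ccc(Cl)nn2)cc1)C1=CCOC1=O` gives 6820 nM
compound 2 `C=C1CC[C@@H]2[C@](C)(COC(C)=O)[C@H](OC(C)=O)CC[C@@]2(C)[C@H]1CC(Nc1ccc(S(=O)(=O)Nc2cc(C)on2)cc1)C1=CCOC1=O` gives 35100 nM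
compound 3 `C=C1CC[C@@H]2[C@](C)(COC(C)=O)[C@H](OC(C)=O)CC[C@@]2(C)[C@H]1CC(Nc1ccc(S(=O)(=O)Nc2ncccn2)cc1)C1=CCOC1=O` gives 19300 nM

Among these three, compound 1 gives the lowest number; its nearest neighbour is compound 3 and the furthest is compound 2. Both measured steps away from compound 1 move the number up: a 5.1-fold higher number from compound 1 to compound 2 (0.71 log units; beyond the scatter) and a 2.8-fold higher number from compound 1 to compound 3 (0.45 log units; beyond the scatter). The step between the two replacing rings, a 1.8-fold lower number from compound 2 to compound 3 (0.26 log units; within the scatter), shows no difference beyond the scatter.

Compound 4 `C=C1CC[C@@H]2[C@](C)(COC(C)=O)[C@H](OC(C)=O)CC[C@@]2(C)[C@H]1CC(Nc1ccc(S(=O)(=O)Nc2nccs2)cc1)C1=CCOC1=O` has not yet been measured in this assay. It differs from compound 1 in one place: 1,3-thiazol-2-yl in place of 6-chloropyridazin-3-yl on a sulfonamide nitrogen. The two measured replacements at the same sulfonamide nitrogen bear on this step; both gave higher numbers than compound 1, the five-membered ring of compound 2 the larger of the two. A five-membered ring again enters here, so a higher number than compound 1 is expected, of a size between the two measured steps; a lower number would go against both. The expected step is a 2.6-fold higher number from compound 1 to compound 4 (0.42 log units; beyond the scatter). For compound 4 in this assay an estimate of 18000 nM is made, with a range from 7000 nM to 45000 nM.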

Compound 4, concentration lethal to 50% of the cells: 43900 nM
Compound 4: the middle estimate sits 2.4-fold (0.39 log units) below what was measured; measured number inside the range.
By their numbers in this assay, from the lowest: compound 1; then compounds 3, 2 and 4 (each within the scatter of the next, the first and the last beyond it).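

With 1,3-thiazol-2-yl on the sulfonamide nitrogen, this assay gives a 6.4-fold higher number from compound 1 to compound 4 (0.81 log units; beyond the scatter) and so a third replacing ring moves the number up, leaving compound 1 lowest among the four, beyond the scatter from each of the others. The new ring also separates partly from the other replacements: a 2.3-fold higher number from compound 3 to compound 4 (0.36 log units; beyond the scatter) lies beyond the scatter, while a 1.3-fold higher number from compound 2 to compound 4 (0.10 log units; within the scatter) lies within it, so the two five-membered rings cannot be told apart, yet no clean split by ring size follows, since compound 2 and compound 3 also stand within the scatter of each other. No measurement at hand accounts for these steps.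

Open, as far as these compounds go, is whether the low number of compound 1 belongs to the pyridazine ring or to its chlorine, a question that plain pyridazin-3-yl or 6-methoxypyridazin-3-yl on the same sulfonamide nitrogen would address. Equally open, from the compounds shown here alone, is whether a chlorine on the five-membered ring, as in 5-chloro-1,3-thiazol-2-yl, would bring the number back towards that of compound 1.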